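Taking the benzyl group off compound 3

The source may report more compounds than this note shows. Statements on the series, on what has been measured and on what is new or still open speak of the compounds shown alone.

In an ADME assay on BJ cells (Homo sapiens) for cytotoxicity, with a stated time of 72 h (on this read-out higher numbers stand for an effect only at larger amounts of compound and lower numbers for an effect already at smaller amounts), compound 1 `Nc1nc(-c2ccccc2)nn1-c1ncnc2ccccc12` gives > 50000 nM, which is a limit. Compound 2 `COc1ccc2ncnc(-n3nc(-c4ccccn4)nc3N)c2c1` gives > 27000 nM, also a limit. Compound 3 `COc1cc2c(-n3nc(-c4ccccn4)nc3N)ncnc2cc1OCc1ccccc1` gives > 27000 nM, again a limit, so compound 3 has no number of its own and stands at the limit of > 27000 nM in this assay, at which 2 of the 3 values shown sit. Compound 4 `COc1cc2c(-n3nc(-c4ccccn4)nc3N)ncnc2cc1O` has hydrogen in place of benzyl on an oxygen on an aromatic ring, benzyloxy to hydroxy (hydrogen in place of benzyl on an oxygen on an aromatic ring). Within the data shown here, the only measured step that bears on this change is a step that the two limits leave unreadable from compound 2 to compound 3, and it involves the same benzyloxy group without showing any size. The expected step, a step that the limit leaves unreadable from compound 3 to compound 4, is therefore none beyond the scatter, in neither direction. Compound 4 is estimated at 30000 nM, with an expected range of 12000 nM to 60000 nM, and will probably be reported as a limit again.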

Compound 4, half-maximal effective concentration in the BJ assay: > 27000 nM
Compound 4 ended at the assay's limit (the forecaster's own chance of this, stated with the estimate: 80%); the middle value does not contradict the limit.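

In the BJ assay compound 4 gives > 27000 nM, which is a limit. Among these compounds, no step from compound 2 or compound 3 to compound 4 can be read. The compounds shown leave open whether benzyloxy, hydroxy or hydrogen makes any difference in the BJ assay. In a physicochemical assay for solubility, in phosphate buffer, with a stated time of 18 h, at pH 7.4 (a higher number here means a more soluble compound, a lower number a less soluble compound), compound 3 gives 68000 nM and compound 4 gives 44000 nM. For the physicochemical assay that is a 1.5-fold lower number from compound 3 to compound 4 (0.19 log units; within the scatter).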